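A few compounds are considered here, and "the series" means these few. Any claim that something is new, unique, unknown or untested is made for them only; others in the source may bear on it.

Three compounds of the series share one core. Compound 1 `Nc1cc(N)c2nc(-c3ccccc3)c(NCc3ccc(F)cc3)nc2c1` carries a (4-fluorobenzyl)amino group; in a functional assay on K562 cells (Homo sapiens) for inhibition, read by sulforhodamine B assay, with a stated time of 48 h (a lower number here means a stronger inhibitor of growth, a higher number a weaker inhibitor of growth), compound 1 gives only a limit, < 100000 nM. Compound 2 `COc1ccc(Sc2nc3cc(N)cc(N)c3nc2-c2ccccc2)cc1` carries a (4-methoxyphenyl)sulfanyl group, and in this assay compound 2 likewise gives only a limit, < 100000 nM. Compound 3 `Nc1cc(N)c2nc(-c3ccccc3)c(Oc3ccc(F)cc3)nc2c1` carries a 4-fluorophenoxy group; in this assay compound 3 also gives only a limit, < 100000 nM. The steps a step that the two limits leave unreadable from compound 1 to compound 2, a step that the two limits leave unreadable from compound 1 to compound 3 and a step that the two limits leave unreadable from compound 2 to compound 3 cannot be sized because of the limit of < 100000 nM in this assay, at which 3 of the 3 values shown sit. Among the measured compounds shown here, compound 3 thus stands at a limit, as do the two other values shown, and no compound can be set apart from another. Compound 4 `Nc1cc(N)c2nc(-c3ccccc3)c(Sc3ccc(F)cc3)nc2c1` differs from compound 3 in one place: (4-fluorophenyl)sulfanyl in place of 4-fluorophenoxy on an aromatic carbon. For the measured compounds named here, no measured step gives a readable size for a change of this kind. The step that the limit leaves unreadable from compound 3 to compound 4 is therefore expected to stay within the scatter. Compound 4 is estimated at 40000 nM in this assay, with a range from 8000 nM to 100000 nM, and is expected most likely to give again only a limit.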

Compound 4, concentration for total growth inhibition: 38900 nM
Estimate against measurement, compound 4: 1.0-fold (0.01 log units) above, and the stated range covers the measured number.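

In this assay, among the compounds shown here, no step to compound 4 from compound 1, compound 2 or compound 3 can be read, because those three compounds give only a limit: the limit of < 100000 nM in this assay, at which 3 of the 4 values shown sit. The compounds shown leave open whether changing the group on this aromatic carbon shifts growth inhibition at all.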